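Chloro in Place of Fluoro at the Far Ring

This account rests on a few compounds, and the source may have more. Where it says the series, first, only, none or still open, it means among the compounds named here.

Of the compounds shown here, three have been measured in a functional assay on CHO cells for agonist activity at Free fatty acid receptor 1 (Homo sapiens), read by FLIPR and calcium flux, in the presence of a further agent that is not named here; on this read-out lower numbers stand for an effect already at smaller amounts and higher numbers for an effect only at larger amounts of compound. Compound 1 `O=C(O)CCc1ccc(OCc2ncc(-c3ccccc3)o2)cc1` gives 1600 nM. Compound 2 `CC(Oc1ccc(CCC(=O)O)cc1)c1nc(-c2ccccc2)no1` gives 2390 nM. Compound 3 `O=C(O)CCc1ccc(OCc2nc(-c3ccc(F)cc3)no2)cc1` gives 680 nM, the lowest number of the three; its gap to compound 1 and its larger gap to compound 2 both lie beyond the usual scatter, so among these three compound 3 acts at the smallest amounts.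

Compound 4 `O=C(O)CCc1ccc(OCc2nc(-c3ccc(Cl)cc3)no2)cc1` is not yet measured. It differs from compound 3 in one place: chloro in place of fluoro on an aromatic carbon. Going by the values given here, no pair of measured compounds shows this change, so there is no measured step to lean on. Such an exchange of one halogen for another is expected to move the number little, and no direction is anticipated. The expected step of a 1.1-fold lower number from compound 3 to compound 4 (0.05 log units; within the scatter) therefore stays within the scatter. For compound 4 the estimate in this assay is 600 nM, with a range from 250 nM to 1500 nM.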

Compound 4, half-maximal effective concentration: 540 nM
Beside the measured number, compound 4's estimate is 1.1-fold (0.05 log units) above it, and the stated range covers the measured number.
By their numbers in this assay, from the lowest: compounds 4 and 3 (each within the scatter of the next); then compounds 1 and 2 (each within the scatter of the next).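

In this assay the change from 4-fluorophenyl to 4-chlorophenyl gives a 1.3-fold lower number from compound 3 to compound 4 (0.10 log units; within the scatter). Going by these compounds alone, this is the first measured comparison here of compounds that differ in one place, and it shows that at this spot on the outer six-membered ring, chloro and fluoro cannot be told apart on this read-out, so either halogen serves equally well. Nothing measured here explains this result.

Still open, as far as these compounds go, is what a methoxy group, a trifluoromethyl group or a nitrile would do at this same place, and how a plain hydrogen there would compare on this same core. Also open, from the compounds shown here alone, is whether the same exchange of fluoro for chloro would read alike on the core of compound 1 or on that of compound 2.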